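The source may report more compounds than this note shows. Statements on the series, on what has been measured and on what is new or still open speak of the compounds shown alone.

In a functional assay on MCF7 cells (Homo sapiens) for inhibition, with a stated time of 48 h (a lower number here means a stronger inhibitor, a higher number a weaker inhibitor), the measured compounds are:
Compound 1 `Cc1cc(C)cc(Sc2c[nH]c3ccc(Cl)cc23)c1` gives 1200 nM
Compound 2 `COc1cc(Sc2c[nH]c3ccc(I)cc23)cc(OC)c1OC` gives 68 nM
Compound 3 `COc1cc(Sc2c[nH]c3ccc(F)cc23)cc(OC)c1OC` gives 160 nM

Compound 3 holds the middle place of these three numbers, higher than compound 2 and lower than compound 1. For the measured compounds named here, compound 4 `COc1ccc2[nH]cc(Sc3cc(OC)c(OC)c(OC)c3)c2c1` is unmeasured and has methoxy in place of fluoro on an aromatic carbon as its one change from compound 3. Going by the values given here, the only measured step at that carbon is a 2.4-fold higher number from compound 2 to compound 3 (0.37 log units; beyond the scatter) and it is modest. Among the compounds with values here, compound 1 differs in more than one place, so it offers no single step. A step no larger than that one is therefore expected in this assay toward a slightly lower number, possibly none beyond the scatter. The expected step is a 1.3-fold lower number from compound 3 to compound 4 (0.12 log units; within the scatter) and it stays within the scatter. Compound 4 is estimated at 120 nM within an expected range from 45 nM to 320 nM.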

Compound 4, half-maximal inhibitory concentration: 22 nM
Compound 4: middle estimate off by 5.5-fold (0.74 log units), on the high side, outside the stated range (below it).
By their numbers in this assay, from the lowest: compound 4; then compound 2; then compound 3; then compound 1.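

In this assay, replacing fluoro with methoxy on this aromatic carbon gives a 7.3-fold lower number from compound 3 to compound 4 (0.86 log units; beyond the scatter), and replacing iodo with methoxy gives a 3.1-fold lower number from compound 2 to compound 4 (0.49 log units; beyond the scatter). The earlier single step compared only two halogens, whereas these steps show that a non-halogen group at this carbon can give a lower number than either of them. No available evidence accounts for this difference. On these data alone, whether ethoxy or an amine at this carbon would keep the lower number remains open, as does whether methoxy would have the same effect on the core of compound 1.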